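Cytotoxicity at the Limit: Hexyloxy to Methylamino

The source may report more compounds than this note shows. Statements on the series, on what has been measured and on what is new or still open speak of the compounds shown alone.

Three compounds have been measured in an ADME assay on BCBL1 cells (Homo sapiens) for cytotoxicity, with a stated time of 7 days; a lower number here means that less compound is tolerated, a higher number that more compound is tolerated:

Compound 1, `CCCCSc1nc(N)nc2c1ncn2/C=C1/CC1(CO)CO`, gives > 20000 nM, which is a limit of the assay rather than a number.
Compound 2, `CCCCNc1nc(N)nc2c1ncn2/C=C1/CC1(CO)CO`, gives > 20000 nM, again a limit.
Compound 3, `CCCCCCOc1nc(N)nc2c1ncn2/C=C1/CC1(CO)CO`, gives > 20000 nM, also a limit.

Compound 3 therefore stands where the other two stand: all three sit at the limit of > 20000 nM in this assay, at which 3 of the 3 values shown sit. Every value shown is a limit, so none of the steps among them can be read: a step that the two limits leave unreadable from compound 1 to compound 2, a step that the two limits leave unreadable from compound 1 to compound 3 and a step that the two limits leave unreadable from compound 2 to compound 3 give neither size nor direction.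

Compound 4, `CNc1nc(N)nc2c1ncn2/C=C1/CC1(CO)CO`, is not yet measured. It differs from compound 3 in one place: methylamino in place of hexyloxy on an aromatic carbon. Among the measured compounds shown here, the steps that bear on this change are the three above, each unreadable, so they fix no size and no direction; they show only that a hexyloxy, a butylamino or a butylsulfanyl at this position all leave the value at the limit. In this assay the estimated step is a step that the limit leaves unreadable from compound 3 to compound 4, expected to be nothing beyond the scatter. Compound 4 is therefore expected to give 40000 nM, within 20000 nM to 150000 nM, and most likely the assay will again report only a limit.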

Compound 4, half-maximal cytotoxic concentration: 67000 nM
Compound 4: the middle estimate sits 1.7-fold (0.22 log units) below what was measured; measured number inside the range.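

No step to compound 4 from compound 1, compound 2 or compound 3 can be read in this assay, because those three compounds give only a limit: the limit of > 20000 nM in this assay, at which 3 of the 4 values shown sit.

The compounds shown leave open whether methylamino on this aromatic carbon differs at all from hexyloxy, butylamino or butylsulfanyl, in either direction.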